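The source may hold more compounds than are shown below. What is called first, only, known or untested is meant among the compounds shown, and "the series" means these compounds.

In a functional assay on U-251 cells (Homo sapiens) for inhibition, read by sulforhodamine B assay, with a stated time of 48 h (on this read-out higher numbers stand for weaker inhibition of growth and lower numbers for stronger inhibition of growth), compound 1 (`CCOC(=O)c1nn(-c2ccc(Cl)cc2)c(-c2ccc(F)cc2)c1CNC(C)(C)C`), which carries the 4-chlorophenyl group, gives 519000 nM; > 537000 nM (2 entries). Compound 2 (`CC(C)(C)NCc1c(C(=O)O)nn(-c2ccccc2)c1-c1ccc(F)cc1`) has no single number and stands only at a limit of the assay, > 680000 nM. Compound 3 (`CC(C)(C)NCc1c(C(=O)O)nn(-c2ccc(Cl)cc2)c1-c1ccc(F)cc1`) differs from compound 2 by chloro in place of hydrogen on an aromatic carbon, phenyl to 4-chlorophenyl. Within the data shown here, no measured pair shows this change, so no shift beyond the scatter is expected in this assay. The expected step, an at least 1.1-fold lower number from compound 2 to compound 3 (0.05 log units; that floor lies within the scatter), is small. For compound 3 the estimated value is 600000 nM, within a range of 350000 nM to 900000 nM, and the assay may report only a limit.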

Compound 3, concentration for 50% growth inhibition: > 623000 nM
Compound 3 ended at the assay's limit; the forecaster's own chance of this, stated with the estimate: 65%; at least 1.0-fold (0.01 log units) between middle value and limit.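

Among these compounds, compound 2 and compound 3 both stand only at limits in this assay, so no step between them can be read. The compounds shown leave open what chloro in place of hydrogen on an aromatic carbon does to growth inhibition.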